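Chloro for Methyl: an Expected Maximal Response for Compound 3

The compounds below may be only part of what the source reports. "The series", "measured", "known", "first", "only" and "open" are said of these compounds alone.

Measured in a functional assay on HEK293 cells for agonist activity at trace amine-associated receptor 1 (Rattus norvegicus), read by cAMP accumulation, with a stated time of 30 min; on this read-out higher numbers stand for larger maximal responses and lower numbers for smaller maximal responses:
Compound 1 `Cc1ccccc1[C@H]1COC(N)=N1` gives 67%.
Compound 2 `Cc1cc(Cl)ccc1[C@H]1COC(N)=N1` gives 93%.

Compound 1 stands lowest of these two numbers; the nearest step is a number 26 percentage points higher from compound 1 to compound 2 (beyond the scatter). Compound 3 `NC1=N[C@@H](c2ccccc2Cl)CO1` differs from compound 1 by chloro in place of methyl on an aromatic carbon. That one measured step adds a chloro while keeping the methyl, so it does not directly cover exchanging methyl for chloro; it only shows that a chloro on this ring can raise the maximal response, from a different place. A step within the scatter, or a slight rise, is therefore expected for compound 3 in this assay: a number 3 percentage points higher from compound 1 to compound 3 (within the scatter). The estimate for compound 3 is 70%, within 45% to 95%.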

Compound 3, largest response reached (Emax), in percent of the reference or control that the assay uses: 105%
Beside the measured number, compound 3's estimate is 35 percentage points below it; measured number above the stated range.
By their numbers in this assay, from the lowest: compound 1; then compound 2; then compound 3.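

In this assay, putting chloro in place of methyl on the aromatic carbon gives a number 38 percentage points higher from compound 1 to compound 3 (beyond the scatter) with a swap of one heavy atom for one heavy atom. Going by these compounds alone, the earlier step added a chloro elsewhere and kept the methyl, so this is the first sign that the group at this very position shapes the maximal response. Nothing measured here explains the rise.

From the compounds shown here alone, whether an amine, a methoxy group or a longer chain at this position would give a similar response stays open.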